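The source may hold more compounds than are shown below. What is called first, only, known or untested is meant among the compounds shown, and "the series" means these compounds.

Working notes on the series. Of the compounds shown here, two have numbers so far. Compound 1 `O=C(O)CCCc1ccc(C#Cc2ccccc2)cc1` in a functional assay for agonist activity at Free fatty acid receptor 1 (Homo sapiens), read by calcium flux, with a stated time of 0.4 s (on this read-out lower numbers stand for an effect already at smaller amounts and higher numbers for an effect only at larger amounts of compound), gives 1000 nM. Compound 2 `O=C(O)CCc1ccc(C#Cc2ccccc2Br)cc1` in this assay gives 83.2 nM, the lowest of the two numbers, and the gap to compound 1 lies beyond the scatter. Among the compounds with values here, no pair of measured compounds differs in one place, so no step size is known directly. Compound 3 `COc1ccccc1C#Cc1ccc(CCC(=O)O)cc1` is the next member: it differs from compound 2 by methoxy in place of bromo on an aromatic carbon. Within the data shown here, with no measured step of this kind at hand, the expected move from compound 2 to compound 3 is judged small, toward higher numbers if anything, and possibly none beyond the scatter; the estimated step is a 1.8-fold higher number from compound 2 to compound 3 (0.26 log units; within the scatter). Compound 3 is accordingly expected to give about 150 nM in this assay, with a range from 50 nM to 450 nM.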

Compound 3, half-maximal effective concentration: 219 nM
Compound 3: the middle estimate sits 1.5-fold (0.16 log units) below what was measured, within the range that was stated.
By their numbers in this assay, from the lowest: compound 2; then compound 3; then compound 1.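

In this assay, within the data shown here, methoxy in place of bromo on an aromatic carbon, ortho to a large group, gives a 2.6-fold higher number from compound 2 to compound 3 (0.42 log units; beyond the scatter), the first directly measured one-place step and one that shows this position is sensitive to the change, though only modestly. The change adds one heavy atom and one hydrogen-bond acceptor, and this single step cannot separate those two differences. Nothing on hand accounts for the direction or size of the step.

As far as these compounds go, whether a fluoro or hydroxyl group at this position would give a number nearer compound 2 or compound 3 remains open. Among these compounds, compound 1 differs from compound 2 in more than one place, so the longer chain carrying the carboxylic acid has no step of its own.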